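Glucagon receptor antagonists: changing the aryl group on the core

A few compounds are considered here, and "the series" means these few. Any claim that something is new, unique, unknown or untested is made for them only; others in the source may bear on it.

Measured compounds:
- compound 1, `C[C@H](c1ccc(C(=O)NCCC(=O)O)cc1)N1C(=O)C(c2cccc(OC(F)(F)F)c2)=N[C@]12CC[C@@H](C(C)(C)C)CC2`: 840 nM
- compound 2, `C[C@H](c1ccc(C(=O)NCCC(=O)O)cc1)N1C(=O)C(c2ccc(F)cc2)=N[C@]12CC[C@@H](C(C)(C)C)CC2`: 430 nM
- compound 3, `CC(C)(C)[C@H]1CC[C@]2(CC1)N=C(c1cccc(Cl)c1)C(=O)N2Cc1ccc(C(=O)NCCC(=O)O)cc1`: 770 nM

These three compounds were tested in a functional assay on CHO cells for antagonist activity at Glucagon receptor (Homo sapiens), read by cAMP accumulation, with stated times of 30 min and 45 min; on this read-out higher numbers stand for weaker inhibition and lower numbers for stronger inhibition. Compound 2 gives the lowest of the three numbers, but its gap to compound 3 and to compound 1 is within the usual scatter, so the three cannot be put in a firm order.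

The new compound is compound 4, `C[C@H](c1ccc(C(=O)NCCC(=O)O)cc1)N1C(=O)C(c2cccc(C3CC3)c2)=N[C@]12CC[C@@H](C(C)(C)C)CC2`. It differs from compound 2 in one place: 3-cyclopropylphenyl in place of 4-fluorophenyl on a carbon with a double bond to nitrogen.

For the measured compounds named here, only one measured step bears on this: a 2.0-fold lower number from compound 1 to compound 2 (0.29 log units; within the scatter), a step that is itself within the scatter. Compound 3, which carries a different aryl group on the same position and a shorter link to the benzoic amide, gives a number close to compound 1. Going by the values given here, both compounds with a group at the 3-position of the phenyl ring gave slightly higher numbers than compound 2, but no step exceeds the scatter.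

Compound 4 is therefore expected to come out near compound 2, probably with a slightly higher number, and the expected step is a 1.6-fold higher number from compound 2 to compound 4 (0.21 log units; within the scatter). The estimate for compound 4 in this assay is 700 nM, with a range from 250 nM to 2000 nM.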

Compound 4, half-maximal inhibitory concentration: 340 nM
Compound 4: the middle estimate sits 2.1-fold (0.31 log units) above what was measured; measured number inside the range.
By their numbers in this assay, from the lowest: compounds 4, 2, 3 and 1 (each within the scatter of the next, the first and the last beyond it).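

In this assay, putting 3-cyclopropylphenyl in place of 4-fluorophenyl on the carbon with a double bond to nitrogen gives a 1.3-fold lower number from compound 2 to compound 4 (0.10 log units; within the scatter), so this position accepts both groups and the measurement cannot separate them. For the compounds shown here, the more telling comparison is between two groups on the same aromatic carbon: cyclopropyl in place of trifluoromethoxy gives a 2.5-fold lower number from compound 1 to compound 4 (0.39 log units; beyond the scatter), a modest step and the first single change in this set to pass beyond the scatter, showing that the choice of group there can shift the number and that a 3-substituted phenyl does not by itself go with a higher number. Nothing available here explains why cyclopropyl and trifluoromethoxy differ in this way.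

The compounds shown leave open how a plain phenyl, or a phenyl carrying an amine or a longer alkyl chain, would read at this position, and whether 4-cyclopropylphenyl would match 3-cyclopropylphenyl. Compound 3 differs from each of the others in more than one place, so its chlorine-bearing ring and its shorter link cannot be weighed separately.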